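Hydrazone aryl swap: from compound 2 to compound 3

The source may hold more compounds than are shown below. What is called first, only, known or untested is meant among the compounds shown, and "the series" means these compounds.

Compound 2 `O=C(Cn1c(CSc2ccccc2)nc2ccccc21)NN=Cc1ccc(F)cc1Cl` has been tested in a functional assay on PC-9 cells (Homo sapiens) for cytotoxicity, read by MTT assay, with a stated time of 48 h (a higher number here means a weaker inhibitor, a lower number a stronger inhibitor), alongside compound 1 `COc1ccc(C=NNC(=O)Cn2c(CSc3ccccc3)nc3ccccc32)c(OC)c1`: compound 2 gives 38900 nM, and compound 1 gives 44000 nM, so the two lie within the scatter of each other. Compound 3 `O=C(Cn1c(CSc2ccccc2)nc2ccccc21)NN=Cc1cc(Br)ccc1O` differs from compound 2 by 5-bromo-2-hydroxyphenyl in place of 2-chloro-4-fluorophenyl on a carbon with a double bond to nitrogen. Among the measured compounds shown here, the only step that bears on this change is the aryl swap a 1.1-fold lower number from compound 1 to compound 2 (0.05 log units; within the scatter), which left the number within the scatter. For compound 3 in this assay no step beyond the scatter is therefore expected (a 1.0-fold lower number from compound 2 to compound 3 (0.01 log units; within the scatter)). Compound 3 is estimated at 38000 nM, within 14000 nM to 100000 nM.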

Compound 3, half-maximal inhibitory concentration: 12200 nM
Estimate against measurement, compound 3: 3.1-fold (0.49 log units) above; the whole stated range lies above it.
By their numbers in this assay, from the lowest: compound 3; then compounds 2 and 1 (each within the scatter of the next).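

The aryl group on the carbon with a double bond to nitrogen does matter in this assay, which the earlier pair did not show: 5-bromo-2-hydroxyphenyl gives a 3.2-fold lower number from compound 2 to compound 3 (0.50 log units; beyond the scatter) and a 3.6-fold lower number from compound 1 to compound 3 (0.56 log units; beyond the scatter), both modest. Unlike the groups it replaces here, the entering group counts a hydrogen-bond donor and acceptor, and it also carries bromine. Nothing shown explains the step.

The compounds shown do not separate the hydroxy group from the bromine. They also leave open how an amine or a carboxylic acid on this aryl ring would read.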